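Butoxy at a meta position on the aniline of compound 1

A few compounds are considered here, and "the series" means these few. Any claim that something is new, unique, unknown or untested is made for them only; others in the source may bear on it.

Measured so far:
compound 1 `O/N=C(/Nc1ccccc1)c1ccc2occc2c1`: 19000 nM
compound 2 `O/N=C(/Nc1ccc(Cl)cc1)c1ccc2occc2c1`: > 30000 nM
compound 3 `O=C(NCC1CCCCC1)c1cccc(N/C(=N/O)c2ccc3occc3c2)c1`: > 30000 nM

Going by the values given here, in an assay on tissue (HeLa cells) for inhibition of Indoleamine 2,3-dioxygenase 1 (Homo sapiens), read by spectrophotometry (on this read-out lower numbers stand for stronger inhibition and higher numbers for weaker inhibition), compound 1 gives 19000 nM, the only plain number in this small set. For compound 2 the assay reports only a limit, > 30000 nM. For compound 3 likewise only a limit is reported, > 30000 nM. Two of the three values therefore sit at the limit of > 30000 nM in this assay, at which 2 of the 3 values shown sit, which leaves the series weak throughout.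

Compound 4 `CCCCOc1cccc(N/C(=N/O)c2ccc3occc3c2)c1` differs from compound 1 by butoxy in place of hydrogen on an aromatic carbon, on an aromatic carbon of a six-membered aromatic ring of carbon only, meta to a large group. Among the compounds with values here, the one counted step in this assay, an at least 1.5-fold higher number from compound 1 to compound 2 (0.19 log units; that floor lies within the scatter), puts a chloro on the same ring and only moves the number toward the limit. Compound 3, which also carries a substituent on that ring, shows only a limit. On this evidence a butoxy is expected to leave compound 4 near compound 1 or push it toward the limit, a step of a 1.3-fold higher number from compound 1 to compound 4 (0.12 log units; within the scatter) in this assay. Compound 4 is therefore estimated at 25000 nM, within 8000 nM to 60000 nM.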

Compound 4, half-maximal inhibitory concentration: > 30000 nM
Compound 4: only a limit was reported (the forecaster's own chance of this, stated with the estimate: 45%); middle value at least 1.2-fold (0.07 log units) away from the limit.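

Butoxy in place of hydrogen, meta to a large group, gives an at least 1.5-fold higher number from compound 1 to compound 4 (0.19 log units; that floor lies within the scatter). The value of compound 4 is a limit and not a number, so the true size of this step cannot be read, and even its floor does not clear the scatter. Among the compounds shown, every one with a group on this ring now gives only a limit, and compound 1, with no such group, alone gives a plain number: the limit of > 30000 nM in this assay, at which 3 of the 4 values shown sit.

As far as these compounds go, it remains open whether a methoxy, a fluoro or an amine at this same position would give a plain number in this assay. Also open, from the compounds shown here alone, is how far past the limit compound 2, compound 3 and compound 4 lie, and so whether they differ from one another at all.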